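The compounds below may be only part of what the source reports. "The series", "measured", "known", "first", "only" and "open" are said of these compounds alone.

In an ADME assay on S9 fraction from liver (Homo sapiens) for metabolic stability, read by LC-MS, using NADPH, with stated times of 5 min and 60 min, tested at 5 uM (a higher number here means that more of the compound is left, a lower number that less of the compound is left), compound 1 (`COc1cc(C2CN(C(=O)c3cc(OC[C@H](O)CO)ccn3)C2)ccc1OCc1ccc(C2CC2)cc1`) gives 64% and compound 2 (`CCc1ccc(COc2ccc(C3CN(C(=O)c4cc(COC[C@@H](O)CO)ccn4)C3)cc2OC)cc1`) gives 54% and these two numbers lie within the usual scatter of each other. Going by the values given here, compound 1 therefore stands level with the only other compound measured. Compound 3 (`COc1cc(C2CN(C(=O)c3cc(COCC(CO)(CO)CO)ccn3)C2)ccc1OCc1ccc(C2CC2)cc1`) keeps the core of compound 1 and differs in one place, on an aromatic carbon of a six-membered aromatic ring with 1 nitrogen, opposite the ring nitrogen. There, (3-hydroxy-2,2-bis(hydroxymethyl)propoxy)methyl stands in place of 2,3-dihydroxypropoxy ((3-hydroxy-2,2-bis(hydroxymethyl)propoxy)methyl in place of 2,3-dihydroxypropoxy on an aromatic carbon). Among the compounds with values here, no measured pair isolates this change, and no step beyond the scatter is expected in this assay in either direction. The estimated step (a number 2 percentage points lower from compound 1 to compound 3 (within the scatter)) is accordingly small. For compound 3 the expected value is 62% with an estimated range from 46% to 78% in this measurement.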

Compound 3, percent of the compound remaining: 85%
Beside the measured number, compound 3's estimate is 23 percentage points below it; measured number above the stated range.
By their numbers in this assay, from the lowest: compounds 2 and 1 (each within the scatter of the next); then compound 3.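

In this assay, going by these compounds alone, the position opposite the ring nitrogen proves responsive: on the core of compound 1, placing (3-hydroxy-2,2-bis(hydroxymethyl)propoxy)methyl where 2,3-dihydroxypropoxy stood gives a number 21 percentage points higher from compound 1 to compound 3 (beyond the scatter), the only step in this set that can be read for a single change. The two earlier compounds differ in more than one place, so they could not show this position on its own. Nothing measured here gives a reason for the step. The change swaps a shorter chain for a larger branched one, leaving open whether the added methyl link or the extra hydroxymethyl arms carry the step. Also open, on these data alone, is how an amine or a carboxylic acid at this position would compare.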